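A few compounds are considered here, and "the series" means these few. Any claim that something is new, unique, unknown or untested is made for them only; others in the source may bear on it.

Compound 1 `COc1cc2cc(Oc3ccc(NC(=O)Nc4ccc(C)cc4)cc3)c(C)nc2cc1OC` and compound 2 `COc1cc2cc(Oc3ccc(NC(=O)Nc4ccc(C(F)(F)F)cc4)cc3)c(C)nc2cc1OC` share one core and differ only in the group on the outer aromatic ring. In a functional assay on NCI-H522 cells (Homo sapiens) for inhibition, read by sulforhodamine B assay, with a stated time of 48 h, tested at 10 uM (a higher number here means a weaker effect of the compound at the concentration tested, a lower number a stronger effect), compound 1 gives 69.9% and compound 2 gives 63.2%. Compound 2 carries the lower of the two numbers, yet the step of a number 6.7 percentage points lower from compound 1 to compound 2 (within the scatter) stays within the scatter. Compound 3 `COc1cc2cc(Oc3ccc(NC(=O)Nc4ccc(Cl)c(C(F)(F)F)c4)cc3)c(C)nc2cc1OC` follows from compound 2 by 4-chloro-3-(trifluoromethyl)phenyl in place of 4-(trifluoromethyl)phenyl on an amide-type nitrogen. For the measured compounds named here, only that one step bears on this change, and it was small; no measured step covers a chlorine entering. The step of a number 5.2 percentage points lower from compound 2 to compound 3 (within the scatter) is therefore expected to be none beyond the scatter. Compound 3 is estimated at 58%, between 38% and 78%.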

Compound 3, a percentage reported as activity, at one concentration (the size of the read-out at that concentration, not a potency): -43.6%
Compound 3: the middle estimate sits 101.6 percentage points above what was measured; the measured number lies below the stated range.
By their numbers in this assay, from the lowest: compound 3; then compounds 2 and 1 (each within the scatter of the next).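

In this assay, 4-chloro-3-(trifluoromethyl)phenyl in place of 4-(trifluoromethyl)phenyl on the amide-type nitrogen gives a number 106.8 percentage points lower from compound 2 to compound 3 (beyond the scatter) and shows that this position can carry a large change, which the step between compounds 1 and 2 did not show. Against 4-methylphenyl, the same group gives a number 113.5 percentage points lower from compound 1 to compound 3 (beyond the scatter) in the same assay. Nothing available here accounts for these steps.

With 4-chlorophenyl and 3-(trifluoromethyl)phenyl absent from the compounds shown, the share of the chlorine and that of the trifluoromethyl placement stay apart from reach. As far as these compounds go, how an amine or a carboxylic acid on this ring would read also remains open.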